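Swapping 4-methoxyphenyl for 6-methoxypyridin-3-yl in the series

The source may report more compounds than this note shows. Statements on the series, on what has been measured and on what is new or still open speak of the compounds shown alone.

In a functional assay on MCF7 cells (Homo sapiens) for antiproliferative activity, read by MTT assay, with a stated time of 72 h (a higher number here means a weaker inhibitor, a lower number a stronger inhibitor), compound 1 (`C/C=C/C(=O)Nc1cccc(Oc2nc(Nc3ccn(C)n3)nc3c2CSCC3)c1`) gives 40000 nM, compound 2 (`C/C=C/C(=O)Nc1cccc(Oc2nc(Nc3cccc(OC)c3)nc3c2CSCC3)c1`) gives 23400 nM and compound 3 (`C/C=C/C(=O)Nc1cccc(Oc2nc(Nc3ccc(OC)cc3)nc3c2CSCC3)c1`) gives 24300 nM. Compound 3 lies within the scatter of both other compounds. Compound 4 (`C/C=C/C(=O)Nc1cccc(Oc2nc(Nc3ccc(OC)nc3)nc3c2CSCC3)c1`) carries 6-methoxypyridin-3-yl in place of 4-methoxyphenyl on a nitrogen on an aromatic ring. Three measured steps at this same place bear on the change: a 1.6-fold lower number from compound 1 to compound 3 (0.22 log units; within the scatter), a 1.7-fold lower number from compound 1 to compound 2 (0.23 log units; within the scatter) and a 1.0-fold higher number from compound 2 to compound 3 (0.02 log units; within the scatter). All three stay within the scatter, so no step beyond the scatter is expected in this assay. The expected size is a 1.1-fold higher number from compound 3 to compound 4 (0.05 log units; within the scatter). The estimated value for compound 4 is 27000 nM, with an expected range of 14000 nM to 50000 nM.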

Compound 4, half-maximal inhibitory concentration: 21100 nM
Estimate against measurement, compound 4: 1.3-fold (0.11 log units) above; low and high end bracket the measured number.
By their numbers in this assay, from the lowest: compounds 4, 2, 3 and 1 (each within the scatter of the next).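

Exchanging the carbon-only ring of 4-methoxyphenyl for the ring with one hetero atom in 6-methoxypyridin-3-yl gives no step beyond the scatter in this assay (a 1.2-fold lower number from compound 3 to compound 4 (0.06 log units; within the scatter)). The comparisons with the other two groups on this nitrogen also stay within the scatter (a 1.1-fold lower number from compound 2 to compound 4 (0.04 log units; within the scatter); a 1.9-fold lower number from compound 1 to compound 4 (0.28 log units; within the scatter)), so the added hydrogen-bond acceptor leaves all four compounds inseparable at this position. Nothing available accounts for this flat result.

Open, going by these compounds, is whether a non-aromatic group on this nitrogen, such as cyclohexyl, would give a step beyond the scatter. The same holds for a carboxylic acid on the aromatic ring.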